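Methylation of a Phenol in a Pyrazole Urea and Amide Series

The compounds below may be only part of what the source reports. "The series", "measured", "known", "first", "only" and "open" are said of these compounds alone.

Of the compounds shown here, three from one series have been measured in a functional assay on U-251 cells (Homo sapiens) for inhibition, read by sulforhodamine B assay, with a stated time of 48 h, tested at 10 uM; on this read-out higher numbers stand for a weaker effect at the one concentration tested and lower numbers for a stronger effect. Compound 1, `O=C(Nc1cccc(-n2cc(-c3ccncc3)c(-c3cc(O)cc(Cl)c3)n2)c1)Nc1ccc(Cl)c(C(F)(F)F)c1`, gives -26.5%. Compound 2, `COc1cc(Cl)cc(-c2nn(-c3cccc(NC(=O)Nc4ccc(Cl)c(C(F)(F)F)c4)c3)cc2-c2ccncc2)c1`, gives -48.3%. Compound 3, `O=C(Nc1cccc(-n2cc(-c3ccncc3)c(-c3cc(O)cc(Cl)c3)n2)c1)c1cc(C(F)(F)F)cc(C(F)(F)F)c1`, carries an amide in place of the urea of compound 1; in this assay compound 3 gives 37.2%, the highest of the three numbers. The difference between the core of compound 1 and the core of compound 3 is not broken down here.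

One change within the set has been measured directly. Between compound 1 and compound 2 the change is methyl in place of hydrogen on an oxygen on an aromatic ring, and the step it made was a number 21.8 percentage points lower from compound 1 to compound 2 (beyond the scatter).

Compound 4, `COc1cc(Cl)cc(-c2nn(-c3cccc(NC(=O)c4cc(C(F)(F)F)cc(C(F)(F)F)c4)c3)cc2-c2ccncc2)c1`, has not yet been measured. It stands to compound 3 as compound 2 stands to compound 1: the change is methyl in place of hydrogen on an oxygen on an aromatic ring, the same change at the same place. Whether the change carries over to the amide core is not known from these data, as the two cores are compared only through the values of compound 1 and compound 3. If it does, the expected step for compound 4 is a number 22.2 percentage points lower from compound 3 to compound 4 (beyond the scatter), resting on the step from compound 1 to compound 2. Compound 4 is therefore estimated at 15% in this assay, with a range from -15% to 45%.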

Compound 4, a percentage reported as activity, at one concentration (the size of the read-out at that concentration, not a potency): 60.7%
The estimate for compound 4 lay 45.7 percentage points below the measured number; the whole stated range lies below it.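

Replacing hydroxy with methoxy did not carry over from the urea core to the amide core. In this assay the amide pair gave a number 23.5 percentage points higher from compound 3 to compound 4 (beyond the scatter), so on this core the 3-chloro-5-methoxyphenyl compound has the weaker effect at the one concentration tested, whereas on the urea core it has the stronger effect. For the compounds shown here, the direction of this change therefore depends on the core that carries it, and the two steps are not one effect seen twice: the same change on two cores in this assay, a number 21.8 percentage points lower (beyond the scatter) from compound 1 to compound 2 and a number 23.5 percentage points higher (beyond the scatter) from compound 3 to compound 4, 45.3 percentage points apart, beyond the scatter of two such steps This does not show which part of the cores decides the direction, since the urea and amide cores differ in their linking group and also in the substituents on the outer aromatic ring, and each core offers only a single pair read in a single assay.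

The compounds shown leave open whether the reversal follows the urea or amide link itself or the chloro and trifluoromethyl substituents on that outer ring. Also open, as far as these compounds go, is how an ethoxy group, a longer alkoxy chain or an amine in place of the hydroxy would behave on each of the two cores.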